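The source may report more compounds than this note shows. Statements on the series, on what has been measured and on what is new or still open speak of the compounds shown alone.

Measured compounds:
Compound 1 `CCC1(Cc2ccccc2)OS(=O)(=O)C=C1OCC(=O)OC` — > 400000 nM
Compound 2 `CCC1(Cc2ccccc2)OS(=O)(=O)C=C1OCc1ccc(Cl)cc1` — >= 50000 nM

In an ADME assay on HEL cells (Homo sapiens) for cytotoxicity, with a stated time of 3 days (a lower number here means that less compound is tolerated, a higher number that more compound is tolerated), compound 1 gives > 400000 nM, which is a limit of the assay and not a number. Compound 2 gives >= 50000 nM, again a limit rather than a measured number. The step that the two limits leave unreadable from compound 1 to compound 2 is therefore unreadable, and compound 2 stands only at its own limit, with no numbered value to place it against. Compound 3 `CCC1(Cc2ccccc2)OS(=O)(=O)C=C1OCc1cccc(Cl)c1` is not yet measured; it carries the same atoms as compound 2, joined differently: 3-chlorophenyl in place of 4-chlorophenyl on a saturated chain carbon bound to an oxygen on an unsaturated carbon. No measured step bears on this change, since the only step shown is the unreadable one from compound 1 to compound 2. Compound 3 is therefore expected to sit at about the same place as compound 2, a step of a number no higher from compound 2 to compound 3 (the limit leaves the size open) no larger than the scatter, with compound 3 estimated at 50000 nM within a range from 25000 nM to 100000 nM.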

Compound 3, minimum cytotoxic concentration: >= 20000 nM
Compound 3 ended at the assay's limit (the forecaster's own chance of this, stated with the estimate: 70%); the middle value lies beyond the limit too.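

The values of compound 1, compound 2 and compound 3 in this assay are all limits of the assay and not numbers, and no step among these compounds can be read. The compounds shown leave open whether the minimum cytotoxic concentration differs between the 4-chlorophenyl, 3-chlorophenyl and methoxycarbonyl groups, and by how much.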